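A few compounds are considered here, and "the series" means these few. Any claim that something is new, unique, unknown or untested is made for them only; others in the source may bear on it.

Series on the shared core `COc1ccc(N)c(C2=NN(C(=O)C3CC3)C(C)(C)S2)c1` of compound 2, which in an assay on isolated protein for inhibition of Nitric oxide synthase, inducible (Homo sapiens), read by scintillation counting, with a stated time of 30 min, tested at 50 uM (a lower number here means less inhibition, a higher number more inhibition at the concentration tested (going by the name of the read-out)), gives 90.1%. Compound 2 sits second highest of the three numbers: compound 3 `COc1ccc(N)c(C2=NN(C(=O)C3CCCCC3)C(C)(C)S2)c1` gives 100%, and the step of a number 9.9 percentage points higher from compound 2 to compound 3 (within the scatter) is within the scatter; compound 1 `CCC(=O)N1N=C(c2cc(OC)ccc2N)SC1(C)C` gives 73%, and the step of a number 17.1 percentage points higher from compound 1 to compound 2 (beyond the scatter) is beyond it. Compound 4 `COc1ccc(N)c(C2=NN(C(=O)c3ccccc3)C(C)(C)S2)c1` is unmeasured and differs from compound 2 thus: phenyl in place of cyclopropyl on a carbonyl carbon. Bearing on it are the steps of a number 17.1 percentage points higher from compound 1 to compound 2 (beyond the scatter) and a number 27 percentage points higher from compound 1 to compound 3 (beyond the scatter), both rises on replacing ethyl with a ring, the larger ring giving the larger rise, and the smaller step of a number 9.9 percentage points higher from compound 2 to compound 3 (within the scatter). A rise of the order a number 4.9 percentage points higher from compound 2 to compound 4 (within the scatter) is therefore expected, the number bounded by the highest value this read-out can report. Compound 4 is estimated at 95% with range 84% to 100%.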

Compound 4, a percentage reported as inhibition, at one concentration (the size of the read-out at that concentration, not a potency): 0%
Compound 4: middle estimate off by 95 percentage points, on the high side; the whole stated range lies above it.
By their numbers in this assay, from the lowest: compound 4; then compound 1; then compounds 2 and 3 (each within the scatter of the next).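

In this assay the position on the carbonyl carbon proves far less forgiving than the ethyl, cyclopropyl and cyclohexyl compounds suggested: phenyl brings a collapse wherever it replaces one of them (a number 90.1 percentage points lower from compound 2 to compound 4 (beyond the scatter); a number 100 percentage points lower from compound 3 to compound 4 (beyond the scatter); a number 73 percentage points lower from compound 1 to compound 4 (beyond the scatter)). The rises over ethyl hold only for the non-aromatic rings, and ring size alone does not carry them, as compound 3 and compound 4 both hold six-membered rings. Nothing in hand explains the loss.

Open, as far as these compounds go, is whether the loss belongs to the aromatic ring directly on the carbonyl carbon. A benzyl group, which sets a methylene between them, would test this.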